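Acetoxy for formyl on a fused aromatic core

A few compounds are considered here, and "the series" means these few. Any claim that something is new, unique, unknown or untested is made for them only; others in the source may bear on it.

Measured compounds:
compound 1, `CC1(C)C=C(n2ccccc2=O)c2cc(C(=O)c3ccccc3)ccc2O1`, 6.21
compound 2, `CC1(C)C=C(n2ccccc2=O)c2cc(C(=O)c3ccco3)ccc2O1`, 5.92
compound 3, `CC1(C)C=C(n2ccccc2=O)c2cc(C=O)ccc2O1`, 6.14

In a functional assay (trachea) with Rattus norvegicus as the target (a higher number here means a more potent compound, by a factor of ten per unit of this negative logarithm, a lower number a less potent compound), compound 3 stands second highest of the three numbers; its nearest neighbour is compound 1, which is a number 0.07 log units lower from compound 1 to compound 3 (within the scatter), and its furthest is compound 2, which is a number 0.22 log units higher from compound 2 to compound 3 (within the scatter). The unmeasured compound 4, `CC(=O)Oc1ccc2c(c1)C(n1ccccc1=O)=CC(C)(C)O2`, differs from compound 3 in one place: acetoxy in place of formyl on an aromatic carbon. For the measured compounds named here, no measured step swaps formyl for acetoxy; the steps that touch this position all vary the group on the carbonyl carbon, and each stayed within the scatter: a number 0.29 log units lower from compound 1 to compound 2 (within the scatter) and the two steps already named. Compound 4 is therefore expected to show a number 0.04 log units lower from compound 3 to compound 4 (within the scatter), with an estimate of 6.1, between 5.5 and 6.7.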

Compound 4, logarithm of the reciprocal of the active concentration, log(1/C): 4.97
Estimate against measurement, compound 4: 1.13 log units above, outside the stated range (below it).
By their numbers in this assay, from the lowest: compound 4; then compounds 2, 3 and 1 (each within the scatter of the next).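

In this assay, formyl, benzoyl and (furan-2-yl)carbonyl had stayed within the scatter of each other, but acetoxy on this aromatic carbon falls clearly away from all three (a number 1.17 log units lower from compound 3 to compound 4 (beyond the scatter); a number 0.95 log units lower from compound 2 to compound 4 (beyond the scatter); a number 1.24 log units lower from compound 1 to compound 4 (beyond the scatter)). The position therefore does respond to what it carries, a difference that varying the group on the carbonyl carbon never revealed. No evidence here bears on why acetoxy behaves differently. The compounds shown leave open whether a hydroxyl, a methoxy or an amide group at this place would stay level with the three carbonyl compounds or fall with compound 4.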